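The compounds below may be only part of what the source reports. "The series", "measured", "known", "first", "only" and "open" are said of these compounds alone.

In a functional assay on HeLa cells (Homo sapiens) for antiproliferative activity, read by MTT assay, with a stated time of 48 h (on this read-out higher numbers stand for weaker inhibition and lower numbers for stronger inhibition), three compounds sharing one core differ only in the amine-bearing chain on an aromatic nitrogen. Compound 1 `CN(C)CCn1c(N)c(-c2nc3cc(Cl)ccc3[nH]2)c2nc(C#N)c(C#N)nc21` gives > 50000 nM, which is a limit of the assay. Compound 2 `CCN(CC)CCn1c(N)c(-c2nc3cc(Cl)ccc3[nH]2)c2nc(C#N)c(C#N)nc21` gives > 50000 nM, which is also a limit. Compound 3 `CN(C)CCCn1c(N)c(-c2nc3cc(Cl)ccc3[nH]2)c2nc(C#N)c(C#N)nc21`, the only one of the three to yield an actual number, gives 16500 nM. The data show an at least 3.0-fold lower number from compound 1 to compound 3 (0.48 log units; beyond the scatter), and also an at least 3.0-fold lower number from compound 2 to compound 3 (0.48 log units; beyond the scatter).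

Compound 4 `CCN(CC)CCCn1c(N)c(-c2nc3cc(Cl)ccc3[nH]2)c2nc(C#N)c(C#N)nc21` keeps the 3-(dimethylamino)propyl framework of compound 3 but exchanges its terminal group: diethylamino in place of dimethylamino on a saturated chain carbon, three bonds along the chain from an aromatic nitrogen. Among the measured compounds shown here, the closest precedent is the same exchange two bonds along the chain, where the data give a step that the two limits leave unreadable from compound 1 to compound 2. That step offers no usable size, and the two steps to compound 3 concern a different change, the longer chain. For the measured compounds named here, no step clearly beyond the scatter is therefore expected, although a drift towards weaker inhibition remains possible. The step expected in this assay is a 1.2-fold higher number from compound 3 to compound 4 (0.08 log units; within the scatter). For compound 4 the estimated value is 20000 nM, with an expected range from 8000 nM to 50000 nM.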

Compound 4, half-maximal inhibitory concentration: 24400 nM
Beside the measured number, compound 4's estimate is 1.2-fold (0.09 log units) below it; the measured number falls inside the stated range.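

In this assay, diethylamino in place of dimethylamino on a saturated chain carbon, three bonds along the chain from an aromatic nitrogen, gives a 1.5-fold higher number from compound 3 to compound 4 (0.17 log units; within the scatter), the first readable size for this exchange, and it leaves the two compounds indistinguishable. The 3-(diethylamino)propyl chain also separates from the shorter chains: going from 2-(diethylamino)ethyl to 3-(diethylamino)propyl gives an at least 2.0-fold lower number from compound 2 to compound 4 (0.31 log units; beyond the scatter), and going from 2-(dimethylamino)ethyl to 3-(diethylamino)propyl gives an at least 2.0-fold lower number from compound 1 to compound 4 (0.31 log units; beyond the scatter), so across these four compounds the readable differences follow chain length and not the terminal amine. The same amine exchange two bonds along the chain still cannot be read, as compound 1 and compound 2 each give only a limit of the assay: the limit of > 50000 nM in this assay, at which 2 of the 4 values shown sit.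

As far as these compounds go, how far the shorter chains actually lie from the 3-aminopropyl pair stays open, since those two steps are only bounds. From the compounds shown here alone, it is also open whether a longer chain, or a cyclic amine such as pyrrolidine or morpholine in place of the diethylamino group, would hold, strengthen or lose the inhibition seen with compound 3 and compound 4.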